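Moving a Fluoro Group on an Aromatic Ring

This account rests on a few compounds, and the source may have more. Where it says the series, first, only, none or still open, it means among the compounds named here.

Compound 1 `Cc1ccc(/C=C2\Cc3ccccc3C2=O)cc1` — 38600 nM
Compound 2 `O=C1/C(=C/c2ccccc2)CCc2ccccc21` — 30200 nM
Compound 3 `O=C1/C(=C/c2cccc(F)c2)CCc2ccccc21` — 31100 nM

The study measured three compounds in a functional assay on P388 cells (Mus musculus) for inhibition; a higher number here means a weaker inhibitor, a lower number a stronger inhibitor. Compound 2 gives the lowest of the three numbers, but compound 3 sits within the scatter of it, and compound 1 also lies within the scatter, so no order among them can be read from these values. Compound 4 `O=C1/C(=C/c2ccc(F)cc2)CCc2ccccc21` has not yet been measured. It differs from compound 2 in one place: fluoro in place of hydrogen on an aromatic carbon.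

Among the compounds with values here, one measured step bears directly on this change. Going from compound 2 to compound 3, the same fluoro in place of hydrogen on an aromatic carbon at another position of the same ring gave a 1.0-fold higher number from compound 2 to compound 3 (0.01 log units; within the scatter), a step that does not rise above the scatter. Within the data shown here, the single fluorine atom, with no ring and no donors or acceptors added, did not move the half-maximal inhibitory concentration there, and there is no other pair among the measured compounds that would suggest a different outcome at the new position.

Compound 4 is therefore expected to show a 1.0-fold lower number from compound 2 to compound 4 (0.00 log units; within the scatter), a step of no real size in either direction. The estimate for compound 4 is 30000 nM, with a range from 15000 nM to 60000 nM.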

Compound 4, half-maximal inhibitory concentration: 15900 nM
Beside the measured number, compound 4's estimate is 1.9-fold (0.28 log units) above it, and the stated range covers the measured number.
By their numbers in this assay, from the lowest: compounds 4, 2, 3 and 1 (each within the scatter of the next, the first and the last beyond it).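

In this assay, within the data shown here, fluoro in place of hydrogen para to a large group gives a 1.9-fold lower number from compound 2 to compound 4 (0.28 log units; within the scatter), so this position, like the one tested with compound 3, yields a step that stays within the scatter. With two positions on the same ring now read, the fluoro change has not produced a step beyond the scatter at either, and compound 4 cannot be separated from compound 2 on these numbers. Nothing available here bears on why this step has the size it has, and a small difference of this kind needs no separate account from these values alone.

The compounds shown leave open whether any replacement at this aromatic carbon can move the number beyond the scatter, as a group larger than a single fluorine atom, such as trifluoromethyl, or one of a different kind, such as an amine or a carboxylic acid, might or might not do. Among these compounds, they also leave open whether a second fluoro on the same ring would give a step any different from the single replacements seen with compound 3 and compound 4.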